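This account rests on a few compounds, and the source may have more. Where it says the series, first, only, none or still open, it means among the compounds named here.

Series notes. Compound 1 `Cc1cc(C)cc(/C=C(\C(=O)c2ccc(Br)cc2)S(=O)(=O)Cc2ccc(F)cc2)c1` and compound 2 `O=C(/C(=C\c1ccc(O)cc1)S(=O)(=O)Cc1ccc(F)cc1)c1ccc(Br)cc1` share one core; compound 3 `Cc1cc(C)cc(/C=C(/SCc2ccc(Cl)cc2)C(=O)c2ccc(Cl)cc2)c1` and compound 4 `O=C(/C(=C\c1ccc(O)cc1)SCc1ccc(Cl)cc1)c1ccc(Cl)cc1` share another, and the difference between the two cores is not broken down here. In a functional assay on DU-145 cells (Homo sapiens) for inhibition, read by trypan blue exclusion, with a stated time of 96 h (on this read-out higher numbers stand for weaker inhibition of growth and lower numbers for stronger inhibition of growth), compound 1 gives 10000 nM. In this assay compound 2 gives 10000 nM. The change between them, (4-hydroxyphenyl in place of 3,5-dimethylphenyl on a double-bonded chain carbon bound to a double-bonded chain carbon), produced a step of no change at the digits printed from compound 1 to compound 2 (within the scatter). In this assay compound 3 gives 10000 nM, level with compound 1 and compound 2 at the digits read. Compound 4 carries the corresponding change on the core of compound 3, (4-hydroxyphenyl in place of 3,5-dimethylphenyl on a double-bonded chain carbon bound to a double-bonded chain carbon); the place is worded identically in both cases, so this is the same change, made twice among the compounds shown. The expectation rests on the measured step of no change at the digits printed from compound 1 to compound 2 (within the scatter), which showed no movement. The matching step is expected to be no change at the digits printed from compound 3 to compound 4 (within the scatter). On that basis compound 4 is estimated at 10000 nM, with a likely range from 5000 nM to 20000 nM. Nothing among the three measured compounds points another way, though all three sit at the same reading.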

Compound 4, concentration for 50% growth inhibition: 10000 nM
Compound 4: the middle estimate sits on the measured number at the digits printed; the range from low to high includes it.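

In this assay the 4-hydroxyphenyl in place of 3,5-dimethylphenyl gives no change at the digits printed from compound 3 to compound 4 (within the scatter) and, set beside the earlier step on the other core, the two steps agree: the same change on two cores in this assay, no change at the digits printed (within the scatter) from compound 1 to compound 2 and no change at the digits printed (within the scatter) from compound 3 to compound 4, 1.0-fold (0.00 log units) apart, within the scatter of two such steps.
Within these four compounds, then, the change carries from one core to the other as an absence of movement, with all four at the same printed reading. This does not show that the change would act alike on a core where the reading moves, as neither step has a size that could be compared, and it does not separate the parts of the difference between the two cores.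

From the compounds shown here alone, it remains open whether another group at this place on the double-bonded chain carbon, such as an amine or a carboxylic acid in place of the hydroxyl on the phenyl ring, would shift growth inhibition away from the shared reading. Going by these compounds, it is also open which part of the difference between the two cores, if any, bears on this read-out.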